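Dropping one hydroxy from a dihydroxy benzothiazole hydrazone

The source may hold more compounds than are shown below. What is called first, only, known or untested is meant among the compounds shown, and "the series" means these compounds.

Measured compounds:
Compound 1, `Oc1ccc(/C=N/Nc2nc3ccccc3s2)cc1O`: > 17500 nM
Compound 2, `Fc1ccc(/C=N/Nc2nc3ccccc3s2)c(F)c1`: > 17200 nM
Compound 3, `Oc1ccc(O)c(/C=N/Nc2nc3ccccc3s2)c1`: 11200 nM

These three compounds share a core and differ only in the groups on the six-membered carbon ring. In a functional assay on HCT-8 cells (Homo sapiens) for cytotoxicity, read by MTT assay, with a stated time of 72 h (a higher number here means a weaker inhibitor, a lower number a stronger inhibitor), compound 1 gives > 17500 nM, which is a limit of the assay rather than a number. Compound 2 likewise gives only a limit, > 17200 nM. For the measured compounds named here, compound 3 is the one compound with a number, 11200 nM. Compound 1 therefore stands at the top of the range of values shown, beside compound 2, and no step between any two of these compounds has been measured.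

Compound 4, `Oc1ccc(/C=N/Nc2nc3ccccc3s2)cc1`, has not yet been measured in this assay. It differs from compound 1 by hydrogen in place of hydroxy on an aromatic carbon. Going by the values given here, with no measured step to lean on, and compound 1 itself at a limit, the expectation is a step of no size beyond the scatter, a step that the limit leaves unreadable from compound 1 to compound 4, most likely again at a limit. Compound 4 is estimated at 20000 nM, within 8000 nM to 50000 nM.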

Compound 4, half-maximal inhibitory concentration: > 18500 nM
Compound 4: no number, only a limit (the forecaster's own chance of this, stated with the estimate: 60%); the middle value does not contradict the limit.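

Compound 1 and compound 4 both give only a limit in this assay, not a number, so the step between them cannot be read. Going by these compounds, whether hydrogen in place of hydroxy on an aromatic carbon changes the result at all, and by how much, stays open.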